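Swapping the Amide Aryl Group for a Fluoropyridine

A few compounds are considered here, and "the series" means these few. Any claim that something is new, unique, unknown or untested is made for them only; others in the source may bear on it.

Compound 1 `CCOc1ccc2nc(NC(=O)COc3ccc4cc(/C=C5/SC(=O)NC5=O)ccc4c3)sc2c1`: 17000 nM
Compound 2 `O=C(COc1ccc2cc(/C=C3/SC(=O)NC3=O)ccc2c1)Nc1ccc(Br)cc1F`: > 50000 nM, a limit of the assay rather than a number
Compound 3 `COc1cccc(NC(=O)COc2ccc3cc(/C=C4/SC(=O)NC4=O)ccc3c2)c1`: 7600 nM

In an assay on isolated protein for inhibition of histone deacetylase 8 (Homo sapiens), with a stated time of 1 h (a lower number here means a stronger inhibitor, a higher number a weaker inhibitor), compound 2 gives only > 50000 nM, which is the limit of > 50000 nM in this assay, at which 1 of the 3 values shown sits. Among the three measured compounds it is the one without a fixed number. For the measured compounds named here, the single measured step that bears on the change considered here is an at least 6.5-fold lower number from compound 2 to compound 3 (0.81 log units; beyond the scatter), where a different aryl group took the same place on the amide nitrogen. Compound 4 `O=C(COc1ccc2cc(/C=C3/SC(=O)NC3=O)ccc2c1)Nc1cccc(F)n1` carries 6-fluoropyridin-2-yl in place of 4-bromo-2-fluorophenyl on an amide-type nitrogen. Because an at least 6.5-fold lower number from compound 2 to compound 3 (0.81 log units; beyond the scatter) showed that changing this aryl group can bring the value into the measurable range, a step of similar direction is expected as an at least 3.3-fold lower number from compound 2 to compound 4 (0.52 log units; beyond the scatter), though its size is uncertain. Compound 4 is therefore estimated at 15000 nM, with a range from 4000 nM to 50000 nM in this assay.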

Compound 4, half-maximal inhibitory concentration: 7200 nM
Compound 4: middle estimate off by 2.1-fold (0.32 log units), on the high side, within the range that was stated.
By their numbers in this assay, from the lowest: compounds 4 and 3 (each within the scatter of the next); then compound 1. At a limit, above all of these: compound 2.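

On the amide nitrogen, a second aryl group now gives a measurable value, with an at least 6.9-fold lower number from compound 2 to compound 4 (0.84 log units; beyond the scatter). A ring with a hetero atom serves here as well as the carbon-only ring of 3-methoxyphenyl, with a 1.1-fold lower number from compound 3 to compound 4 (0.02 log units; within the scatter), so these two groups cannot be told apart. The true size of the first step stays unknown because compound 2 has only a limit: the limit of > 50000 nM in this assay, at which 1 of the 4 values shown sits.

The compounds shown do not separate the effect of the ring nitrogen from that of losing the bromine. Going by these compounds, what an amine or a carboxylic acid on this ring would do also remains open.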